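Adding a Butyl Extension to Compound 2

The compounds below may be only part of what the source reports. "The series", "measured", "known", "first", "only" and "open" are said of these compounds alone.

In a functional assay on SW480 cells (Homo sapiens) for antiproliferative activity, read by MTT assay, with a stated time of 48 h (on this read-out higher numbers stand for weaker inhibition and lower numbers for stronger inhibition), compound 1 (`CCCCCC(CCO)n1cnc2c(Cl)ncnc21`) gives > 50000 nM, which is a limit and not a number. Compound 2 (`CCCCCC(CCO)n1c(Br)nc2c(Cl)ncnc21`) gives 23800 nM and compound 3 (`CCCCCCCCCC(CCO)n1cnc2c(Cl)nc(F)nc21`) gives 12500 nM, two values within the scatter of each other. Going by the values given here, the only measured step, bromo in place of hydrogen on an aromatic carbon, is an at least 2.1-fold lower number from compound 1 to compound 2 (0.32 log units; beyond the scatter). It does not touch the chain. Compound 4 (`CCCCCCCCCC(CCO)n1c(Br)nc2c(Cl)ncnc21`) keeps the bromo of compound 2 and changes the chain: butyl in place of hydrogen on a saturated chain carbon, six bonds along the chain from an aromatic nitrogen. Among the compounds with values here, no measured step isolates this change. Compound 3 has the same longer chain but also differs in the core, and it gives 12500 nM, so only a modest change is expected. The expected step in this assay is a 2.4-fold lower number from compound 2 to compound 4 (0.38 log units; beyond the scatter), towards a lower number. For compound 4 the estimated value is 10000 nM, with an expected range from 3500 nM to 25000 nM.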

Compound 4, half-maximal inhibitory concentration: 25000 nM
Estimate against measurement, compound 4: 2.5-fold (0.40 log units) below; low and high end bracket the measured number.
By their numbers in this assay, from the lowest: compounds 3, 2 and 4 (each within the scatter of the next). At a limit, above all of these: compound 1.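

In this assay, going by these compounds alone, this is the first step that changes the chain alone: a 1.1-fold higher number from compound 2 to compound 4 (0.02 log units; within the scatter) and so stays within the scatter. With the bromo kept, adding butyl at this carbon, six bonds along the chain from an aromatic nitrogen, produces no difference this read-out can separate from compound 2. Nothing measured here bears on why the number holds. From the compounds shown here alone, whether butyl would behave the same without the bromo remains open. So does whether a chain ending in an amine or a carboxylic acid would shift the number.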